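Dimethoxyphenyl for Hydroxyphenyl on a Purine Growth Inhibitor

The source may report more compounds than this note shows. Statements on the series, on what has been measured and on what is new or still open speak of the compounds shown alone.

Measured compounds:
compound 1, `CC(C)CCn1cnc2c(Nc3cccc(O)c3)nc(N[C@H]3CC[C@H](N)CC3)nc21`, 7600 nM
compound 2, `CCCCn1cnc2c(Nc3cccc(Cl)c3)nc(N[C@H]3CC[C@H](N)CC3)nc21`, 2000 nM
compound 3, `CCCCCCn1cnc2c(Nc3ccc(Cl)cc3)nc(N[C@H]3CC[C@H](N)CC3)nc21`, 2100 nM

In a functional assay on K562 cells (Homo sapiens) for inhibition, read by fluorescence, with a stated time of 72 h (a lower number here means a stronger inhibitor of growth, a higher number a weaker inhibitor of growth), compound 1 gives 7600 nM, the highest of the three numbers and therefore the weakest growth inhibitor of the set. Among the measured compounds shown here, compound 2 gives 2000 nM and compound 3 gives 2100 nM; both lie beyond the scatter from compound 1, but each differs from compound 1 in more than one place, so no single step between measured compounds can be drawn.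

Compound 4, `COc1cc(Nc2nc(N[C@H]3CC[C@H](N)CC3)nc3c2ncn3CCC(C)C)cc(OC)c1`, has not yet been measured in this assay. It differs from compound 1 in one place: 3,5-dimethoxyphenyl in place of 3-hydroxyphenyl on a nitrogen on an aromatic ring. Because compound 1 sits at 7600 nM while the two chloro-bearing compounds sit lower, a change at this same ring is the most natural place to expect movement, though the direction cannot be fixed from one-place steps.

Compound 4 is expected to give about 4000 nM, estimated to fall between 1200 nM and 13000 nM. This estimate means a step of a 1.9-fold lower number from compound 1 to compound 4 (0.28 log units; within the scatter), expected to be a modest lowering, near the edge of the scatter.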

Compound 4, concentration for 50% growth inhibition: 2500 nM
The estimate for compound 4 lay 1.6-fold (0.20 log units) above the measured number; the range from low to high includes it.
By their numbers in this assay, from the lowest: compounds 2, 3 and 4 (each within the scatter of the next); then compound 1.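

Among the compounds shown here, this is the first single-place step in the set: in this assay, putting 3,5-dimethoxyphenyl in place of 3-hydroxyphenyl on a nitrogen on an aromatic ring gives a 3.0-fold lower number from compound 1 to compound 4 (0.48 log units; beyond the scatter), which shows that the number responds to the group at this position while the rest of compound 1 stays the same. The step exchanges a hydrogen-bond donor for more hydrogen-bond acceptors and also adds heavy atoms, so this single comparison cannot separate these differences. Nothing measured here explains the lower number.

As far as these compounds go, it remains open whether 3-methoxyphenyl or 3,5-dihydroxyphenyl at this position would give a similar number, which would help show whether the loss of the hydroxyl or the presence of the methoxy groups tracks the change. From the compounds shown here alone, it also remains open whether the same exchange would give a similar step on a core carrying a butyl or hexyl chain.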